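The source may hold more compounds than are shown below. What is called first, only, known or untested is meant among the compounds shown, and "the series" means these compounds.

Measured so far in a functional assay for activation of Alpha-1D adrenergic receptor (Homo sapiens), read by calcium flux; on this read-out higher numbers stand for an effect only at larger amounts of compound and lower numbers for an effect already at smaller amounts:
Compound 1 `CCN(CC)C(=O)c1ccccc1OCC1=NCCN1` gives < 5020 nM, which is a limit of the assay.
Compound 2 `c1ccc(-c2cnccn2)c(OCC2=NCCN2)c1` gives < 100000 nM, also a limit of the assay.
Compound 3 `c1coc(-c2ccccc2OCC2=NCCN2)c1` gives < 100000 nM, again a limit of the assay.

Compound 2 therefore does not stand at a number at all in this assay: it sits at the limit of < 100000 nM in this assay, at which 2 of the 3 values shown sit. Compound 1 sits at the limit of < 5020 nM in this assay, at which 1 of the 3 values shown sits. Within the data shown here, compound 3 shares the same limit as compound 2, so the one change already measured around compound 2, a step that the two limits leave unreadable from compound 2 to compound 3, cannot be read as a step of any size in either direction.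

The new compound, compound 4 `c1ccc(-c2nccs2)c(OCC2=NCCN2)c1`, differs from compound 2 in a single place: 1,3-thiazol-2-yl in place of pyrazin-2-yl on an aromatic carbon. Among the measured compounds shown here, the only measured step that bears on this kind of change, the exchange of the pyrazin-2-yl for another small aromatic ring, is the unreadable one from compound 2 to compound 3, so no size and no direction can be expected from the data in hand.

The expectation for compound 4 in this assay is therefore simply that it lands in the same region as compound 2, most likely again only as a limit. Its estimated step is a step that the limit leaves unreadable from compound 2 to compound 4. The estimate for compound 4 is 20000 nM, expected to fall between 2000 nM and 100000 nM.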

Compound 4, half-maximal effective concentration: 31.6 nM
Beside the measured number, compound 4's estimate is 630-fold (2.80 log units) above it, and the stated range ends above it.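

In this assay, among these compounds, compound 4 has a measured number, but compound 2 and compound 3 stand only as limits of the assay, so no step from either of them to compound 4 can be read. The compounds shown leave open how large the change to 1,3-thiazol-2-yl is, and in which direction it runs.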